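The source may hold more compounds than are shown below. What is called first, only, known or untested is meant among the compounds shown, and "the series" means these compounds.

Compound 1, `CCOC(=O)COc1cc(O)c2c(=O)c(O)c(-c3ccc(OC)cc3)oc2c1CC=C(C)C`, is one of three close relatives built on the same core and differing only in the groups hung from its oxygens. In a functional assay on A549 cells (Homo sapiens) for cytotoxicity, read by MTT assay (a higher number here means a weaker inhibitor, a lower number a stronger inhibitor), compound 1 gives 41600 nM. Compound 3, `COc1ccc(-c2oc3c(CC=C(C)C)c(OCCCC(=O)O)cc(O)c3c(=O)c2OCCCC(=O)O)cc1`, carries two acid-tipped chains and gives 26000 nM; the gap between compound 1 and compound 3 lies within the usual scatter, so neither stands apart from the other. For compound 2, `COc1ccc(-c2oc3c(CC=C(C)C)c(OCCCO)cc(O)c3c(=O)c2OCCCO)cc1`, this assay reports only a limit, > 100000 nM, which is the limit of > 100000 nM in this assay, at which 1 of the 3 values shown sits.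

The step to compound 4, `COc1ccc(-c2oc3c(CC=C(C)C)c(OC/C=C/C(=O)O)cc(O)c3c(=O)c2O)cc1`, is 2-carboxyethenyl in place of ethoxycarbonyl on a saturated chain carbon bound to an oxygen on an aromatic ring. Within the data shown here, no measured pair in this set shows the effect of such a swap, and since compound 3, which also ends in carboxylic acids, sits so close to compound 1, the expectation is that the number will stay where compound 1 already lies. Compound 4 is thus expected to give 40000 nM, most likely between 15000 nM and 100000 nM. That estimate implies a step of a 1.0-fold lower number from compound 1 to compound 4 (0.02 log units; within the scatter), expected to stay within the scatter.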

Compound 4, half-maximal inhibitory concentration: 22900 nM
Estimate against measurement, compound 4: 1.7-fold (0.24 log units) above; the range from low to high includes it.
By their numbers in this assay, from the lowest: compounds 4, 3 and 1 (each within the scatter of the next). At a limit, above all of these: compound 2.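

In this assay, among these compounds, this is the first pair of compounds that differ in only one place, and it gives a 1.8-fold lower number from compound 1 to compound 4 (0.26 log units; within the scatter). On this saturated chain carbon bound to an oxygen on an aromatic ring, then, 2-carboxyethenyl can take the place of ethoxycarbonyl without a shift beyond the scatter, even though the new group adds a hydrogen-bond donor and a second double bond outside the aromatic rings. Nothing measured here explains why the two groups read alike.

As far as these compounds go, the double bond and the carboxylic acid arrive together in this one step, so the share of each remains open. Also open, from the compounds shown here alone, is how an amide or an amine at the end of this chain would read in this assay on the same core.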